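The source may report more compounds than this note shows. Statements on the series, on what has been measured and on what is new or still open speak of the compounds shown alone.

Measured compounds in a functional assay on K562 cells (Homo sapiens) for antiproliferative activity, read by MTT assay, with a stated time of 72 h; a higher number here means a weaker inhibitor, a lower number a stronger inhibitor:
- compound 1, `COc1ccccc1-c1ncnn1-c1cc(OC)c(OC)c(OC)c1`: > 10000 nM.
- compound 2, `COc1cc(-c2ncnn2-c2cccc(N)c2)cc(OC)c1OC`: > 10000 nM.
- compound 3, `COc1cc(-c2ncnn2-c2ccc(F)cc2)cc(OC)c1OC`: > 10000 nM.

For compound 1 the value is a limit of the assay, not a number. The same holds for compound 2 and for compound 3, so all three sit at the limit of > 10000 nM in this assay, at which 3 of the 3 values shown sit, and none can be ranked against the others. Among the compounds with values here, the only measured step, a step that the two limits leave unreadable from compound 2 to compound 3, is therefore unreadable.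

Compound 4, `COc1cc(-n2ncnc2-c2ccc(SC)cc2)cc(OC)c1OC`, is not yet measured. It arises from compound 1 through (4-(methylsulfanyl)phenyl in place of 2-methoxyphenyl on an aromatic carbon). Within the data shown here, no measured step touches this change, so nothing points to a direction, and the three limits suggest that the next value may also be a limit. Compound 4 is expected at 8000 nM, between 1000 nM and 30000 nM, a step of an at least 1.2-fold lower number from compound 1 to compound 4 (0.09 log units; that floor lies within the scatter) that is an estimate only.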

Compound 4, half-maximal inhibitory concentration: 340 nM
For compound 4 the middle estimate is 24-fold (1.37 log units) above the measured one; measured number below the stated range.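

On an aromatic carbon of the five-membered ring, this position responds to its substituent: 4-(methylsulfanyl)phenyl in place of 2-methoxyphenyl gives an at least 29-fold lower number from compound 1 to compound 4 (1.46 log units; beyond the scatter) in this assay. Compound 4 is therefore the first compound here with a readable number rather than a limit, and the steps among the others cannot be read: the limit of > 10000 nM in this assay, at which 3 of the 4 values shown sit.

This one change swaps sulfur for oxygen and also moves the group on the phenyl ring, and the compounds shown do not separate the two. Going by these compounds, how an ethylsulfanyl chain or a carboxylic acid would fare in place of the methylsulfanyl also stays open.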